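The source may hold more compounds than are shown below. What is called first, only, known or untested is meant among the compounds shown, and "the series" means these compounds.

The study concerns an assay on isolated protein for inhibition of Ephrin type-B receptor 4 (Homo sapiens), read by HTRF, tested at 10 uM; a lower number here means less inhibition, a higher number more inhibition at the concentration tested (going by the name of the read-out). Compound 1, with the structure `CN(CCCn1ccnc1)C(=O)[C@@H]1CCCN1c1nccc(Nc2ccccc2)n1`, gives 0% in this assay. Two further compounds were measured alongside it: compound 2, with the structure `Cc1cccc(Oc2ccnc(N3CCC[C@H]3C(=O)NCCCn3ccnc3)n2)c1`, gives 0% in this assay, and compound 3, with the structure `Cc1cccc(N(C)c2cc(Nc3cccc(C(=O)N(CC(C)C)CC(C)C)c3)ncn2)c1`, gives 0% in this assay. Among the compounds with values here, compound 1 therefore stands level with both at the digits recorded, and no difference between any pair of the three reaches beyond the scatter of the measurement, so the inhibition in this assay is level across all three and none of them can be said to give a higher or lower number than another.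

The unmeasured compound 4, with the structure `CN(C)CC(C)(C)CNC(=O)[C@@H]1CCCN1c1nccc(Nc2ccccc2)n1`, is related to compound 1 by a single change on a carbonyl carbon whose other neighbour is a saturated ring carbon: (2-((dimethylamino)methyl)-2-methylpropyl)amino in place of (3-(1H-imidazol-1-yl)propyl)(methyl)amino on a carbonyl carbon. Because compound 1 gives 0% and the other two compounds sit at the same level, the author expects the step of a number 3 percentage points higher from compound 1 to compound 4 (within the scatter) to be small and not to rise beyond the scatter. Compound 4 is estimated to give 3% in this assay, within a range from 0% to 15%.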

Compound 4, a percentage reported as inhibition, at one concentration (the size of the read-out at that concentration, not a potency): 0%
Estimate against measurement, compound 4: 3 percentage points above; the measured number falls inside the stated range.
By their numbers in this assay, from the lowest: compounds 1, 2, 3 and 4 (each within the scatter of the next).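

In this assay, within the data shown here, the change on a carbonyl carbon whose other neighbour is a saturated ring carbon gives the first single-place comparison in the set, no change at the digits printed from compound 1 to compound 4 (within the scatter). It shows that, on the core of compound 1, (2-((dimethylamino)methyl)-2-methylpropyl)amino in place of (3-(1H-imidazol-1-yl)propyl)(methyl)amino does not lift the reading, even though the five-membered aromatic ring goes and the entering group has no ring and brings a hydrogen-bond donor. As compound 1 gives 0% and compound 4 gives 0%, this step cannot tell whether either group matters at this position.

Going by these compounds, whether a morpholine or a carboxylic acid on the same carbonyl carbon would give a reading above the scatter remains open. No measurement shown bears on the reason for this result.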